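A few compounds are considered here, and "the series" means these few. Any claim that something is new, unique, unknown or untested is made for them only; others in the source may bear on it.

Working notes on the series: one group on an aromatic carbon varies while the shared core stays fixed. In a functional assay with Cavia porcellus as the target (a lower number here means that less compound is needed, a higher number that more compound is needed for the effect), the fluoro member compound 1 (`COC(=O)c1c(C)[nH]c(C)c1C(=O)c1ccccc1F`) gives (70000 nM), the iodo member compound 2 (`COC(=O)c1c(C)[nH]c(C)c1C(=O)c1ccccc1I`) gives (5900 nM) and the chloro member compound 3 (`COC(=O)c1c(C)[nH]c(C)c1C(=O)c1ccccc1Cl`) gives (14000 nM). Compound 3 therefore sits in the middle of the three numbers, second highest.

Next comes compound 4 (`COC(=O)c1c(C)[nH]c(C)c1C(=O)c1ccccc1C`), with methyl in place of chloro on an aromatic carbon, ortho to a large group (methyl in place of chloro on an aromatic carbon).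

For the measured compounds named here, three measured steps bear on this place. The widest is a 12-fold lower number from compound 1 to compound 2 (1.07 log units; beyond the scatter) and the other two are a 5.0-fold lower number from compound 1 to compound 3 (0.70 log units; beyond the scatter) and a 2.4-fold higher number from compound 2 to compound 3 (0.38 log units; beyond the scatter) in this assay. Across these three compounds the number falls from fluoro through chloro to iodo, and none of them goes against that order. Going by the values given here, none of the measured compounds carries methyl, however, so the steps show only how far a change at this place has moved the number, not the direction for this swap.

No firm direction is expected, and the expectation stays close to compound 3 with a wide margin. The expected step is a 1.1-fold higher number from compound 3 to compound 4 (0.06 log units; within the scatter) and so is not expected to stand clear of the scatter. Compound 4 is estimated at 16000 nM with an expected range from 5000 nM to 50000 nM in this assay.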

Compound 4, half-maximal effective concentration: 9470 nM
The estimate for compound 4 lay 1.7-fold (0.23 log units) above the measured number; measured number inside the range.
By their numbers in this assay, from the lowest: compounds 2, 4 and 3 (each within the scatter of the next, the first and the last beyond it); then compound 1.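

In this assay, for the compounds shown here, methyl is the first group at this place that is not a halogen, and it falls in with chloro and iodo: a 1.5-fold lower number from compound 3 to compound 4 (0.17 log units; within the scatter) and a 1.6-fold higher number from compound 2 to compound 4 (0.21 log units; within the scatter) both stay within the scatter, even though compound 2 and compound 3 lie beyond the scatter of each other. Fluoro alone now stands apart, with a 7.4-fold lower number from compound 1 to compound 4 (0.87 log units; beyond the scatter), so at this place compound 1 is the only member set clear of all the others, and a halogen is not needed to reach the range of compound 2 and compound 3. No measurement shown explains why methyl and chloro, one heavy atom each and with no hydrogen-bond donors or acceptors, cannot be told apart here.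

On these data alone, it remains open whether a group carrying hydrogen-bond donors or acceptors at this place, such as an amine or a carboxylic acid, would stay with compound 2, compound 3 and compound 4 or move away from them. Also unsettled are a longer chain such as ethyl or propyl here, and whether the same grouping of substituents would hold at other places on the shared core.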